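A few compounds are considered here, and "the series" means these few. Any claim that something is new, unique, unknown or untested is made for them only; others in the source may bear on it.

In a functional assay on KU812 cells (Homo sapiens) for antiproliferative activity (a higher number here means a weaker inhibitor, a lower number a stronger inhibitor), three compounds have been measured: compound 1 `Cc1ccc(C(=O)Nc2cc(-n3ccnc3)cc(C(F)(F)F)c2)cc1Nc1nc(-c2cccnc2)cs1` gives 36 nM, compound 2 `Cc1ccc(C(=O)Nc2cc(-c3cnn(C)c3)cc(C(F)(F)F)c2)cc1Nc1nc(-c2cccnc2)cs1` gives 27.1 nM, and compound 3 `Cc1cc(NC(=O)c2ccc(C)c(Nc3nc(-c4cccnc4)cs3)c2)cc(-n2cnc(C)c2)c1` gives 871 nM.

Compound 3 stands highest of the three, and its gaps to compound 1 and compound 2 lie beyond the scatter. Compound 4 `Cc1cn(-c2cc(NC(=O)c3ccc(C)c(Nc4nc(-c5cccnc5)cs4)c3)cc(C(C)(C)C)c2)cn1` differs from compound 3 by tert-butyl in place of methyl on an aromatic carbon. Within the data shown here, the only measured step, a 1.3-fold lower number from compound 1 to compound 2 (0.12 log units; within the scatter), concerns another position and lies within the scatter, so no measured step bears on a methyl to tert-butyl exchange. Compound 1 and compound 2 carry trifluoromethyl where compound 3 carries methyl, but they also differ from compound 3 elsewhere, so their lower numbers cannot be tied to that position alone. Compound 4 is therefore expected near compound 3, with a 1.9-fold lower number from compound 3 to compound 4 (0.29 log units; within the scatter) estimated and a value of 450 nM (range 120 nM to 1700 nM).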

Compound 4, half-maximal inhibitory concentration: 11 nM
Compound 4: the middle estimate sits 41-fold (1.61 log units) above what was measured; the whole stated range lies above it.
By their numbers in this assay, from the lowest: compound 4; then compounds 2 and 1 (each within the scatter of the next); then compound 3.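

In this assay, among these compounds, the position on the six-membered aromatic ring, meta to the 4-methyl-1H-imidazol-1-yl group, proves highly sensitive to its substituent: tert-butyl in place of methyl gives a 79-fold lower number from compound 3 to compound 4 (1.90 log units; beyond the scatter) and is the first measured change here. This step is also the only one shown that lies beyond the scatter. Nothing available explains the size of this step. Open, from the compounds shown here alone, is how isopropyl or cyclopropyl would behave at this position. Also open, going by these compounds, is whether an amine or a carboxylic acid there would keep so low a number.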